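Amide replacement at the carbonyl of compound 2

A few compounds are considered here, and "the series" means these few. Any claim that something is new, unique, unknown or untested is made for them only; others in the source may bear on it.

The series shares one core, seen in compound 2 `CCOC(=O)CN(C)C(=O)c1ccc(C(CC)(CC)c2ccc(OCC(O)C(C)(C)C)c(C)c2)n1CC` and in compound 3 `CCn1c(C(=O)OC(C)CCO)ccc1C(CC)(CC)c1ccc(OCC(=O)C(C)(C)C)c(C)c1`. In an assay on HL-60 cells for agonist activity at vitamin D3 receptor (Homo sapiens), read by microscopy, with a stated time of 96 h (a lower number here means that less compound is needed, a higher number that more compound is needed for the effect), compound 2 gives 210 nM, the lowest of the two numbers in hand. Compound 3 gives 380 nM, which is within the scatter of compound 2. Compound 1 `CCOC(=O)CN(C)C(=O)c1ccc(C(CC)(CC)c2ccc(OCC(=O)C(C)(C)C)c(C)c2)n1CC` returns only a limit in this assay, > 50000 nM. The step of an at least 230-fold lower number from compound 1 to compound 2 (2.37 log units; beyond the scatter) changes the side chain and is large, as is an at least 130-fold lower number from compound 1 to compound 3 (2.11 log units; beyond the scatter), which alters the carbonyl substituent; both start from the limit of compound 1 (the limit of > 50000 nM in this assay, at which 1 of the 3 values shown sits), so their true size is open.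

Compound 4 `CCn1c(C(=O)Nc2cccc(C(F)(F)F)c2)ccc1C(CC)(CC)c1ccc(OCC(O)C(C)(C)C)c(C)c1` differs from compound 2 at the carbonyl: (3-(trifluoromethyl)phenyl)amino in place of ((ethoxycarbonyl)methyl)(methyl)amino on a carbonyl carbon. Within the data shown here, only the step from compound 1 to compound 3 touches that carbonyl, and it began from a limit, so the data give little guide for this exchange. A modest step within or near the scatter is expected, a 1.1-fold lower number from compound 2 to compound 4 (0.02 log units; within the scatter). Compound 4 is therefore estimated at 200 nM, with a range from 50 nM to 1200 nM.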

Compound 4, half-maximal effective concentration: > 50000 nM
Compound 4: no number, only a limit (the forecaster's own chance of this, stated with the estimate: 10%); at least 250-fold (2.39 log units) between middle value and limit.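

Compound 2 carries the 1-hydroxy-2,2-dimethylpropyl side chain that is also present in compound 4, and the exchange on the carbonyl carbon gives an at least 230-fold higher number from compound 2 to compound 4 (2.37 log units; beyond the scatter). Among these compounds, the only earlier step at this carbonyl started from a limit and led to a lower number, whereas this one starts from a measured value and shows that a change here can also lead to a far higher number. Compound 4 gives > 50000 nM, which is a limit and not a number, so the true size of the step is open: the limit of > 50000 nM in this assay, at which 2 of the 4 values shown sit.

The exchange alters the aromatic ring, the trifluoromethyl and the amide hydrogen at once, and the compounds shown do not separate them. Going by these compounds, how an unsubstituted phenylamino, a methyl(phenyl)amino or a carboxylic acid at this carbonyl would read remains open.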